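A biaryl replaces a halogen on a quinolinone amide

The source may hold more compounds than are shown below. What is called first, only, known or untested is meant among the compounds shown, and "the series" means these compounds.

Three close relatives of one shared core have been tested, and none gave a number. In a functional assay on KYSE-410 cells (Homo sapiens) for antiproliferative activity, read by MTT assay, with a stated time of 72 h (on this read-out lower numbers stand for stronger inhibition and higher numbers for weaker inhibition), compound 1 `O=C(c1cc(=O)[nH]c2cc(Br)ccc12)N1CCCCC1` reached only the limit > 20000 nM. Compound 2 `O=C(Nc1cccc(C(F)(F)F)c1)c1cc(=O)[nH]c2cc(Br)ccc12` likewise stopped at the limit > 20000 nM. Compound 3 `O=C(Nc1cccc(F)c1)c1cc(=O)[nH]c2cc(F)ccc12` also sits at the limit > 20000 nM, so its standing is a ceiling, not a value; all three share (the limit of > 20000 nM in this assay, at which 3 of the 3 values shown sit). Compound 4 `Cc1ccc(-c2ccc3c(C(=O)Nc4cccc(F)c4)cc(=O)[nH]c3c2)cc1` carries a much larger group: 4-methylphenyl in place of fluoro on an aromatic carbon. For the measured compounds named here, no measured step shows what such a change does here. The expectation is a modest gain in this assay, since a limit leaves room only downward, with the step from compound 3 to compound 4 estimated at an at least 2.5-fold lower number from compound 3 to compound 4 (0.39 log units; beyond the scatter). Compound 4 is therefore expected near 8000 nM, between 1500 nM and 20000 nM.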

Compound 4, half-maximal inhibitory concentration: > 20000 nM
Compound 4: only a limit was reported; the forecaster's own chance of this, stated with the estimate: 50%; at least 2.5-fold (0.39 log units) between middle value and limit.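

Compound 3 and compound 4 both end at a limit, so the step between them cannot be read: (the limit of > 20000 nM in this assay, at which 4 of the 4 values shown sit). The compounds shown leave open whether any change on the shared core gives a real number in this assay at all.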